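Cytotoxicity notes: benzyl replacement on the shared amine

This account rests on a few compounds, and the source may have more. Where it says the series, first, only, none or still open, it means among the compounds named here.

Compound 2 `CCc1ccc2[nH]c(=O)c(CN(Cc3ccc(OCOC)cc3)Cc3ccc(C(C)(C)C)cc3)cc2c1` gives, in a toxicity assay on MDCK cells (Canis lupus familiaris) for cytotoxicity, read by crystal violet staining, with a stated time of 48 h (on this read-out lower numbers stand for higher toxicity in this test and higher numbers for lower toxicity in this test), only a limit of the test, > 10000 nM; it is one of two limits in this set, and nothing further can be read from it. Compound 1 `COCOc1ccc(CN(Cc2ccc(C(C)(C)C)cc2)Cc2cc3cc(C)ccc3[nH]c2=O)cc1` gives 6400 nM in this assay. Compound 3 `CSc1ccc(CN(Cc2ccc(C(C)(C)C)cc2)Cc2cc3cc(C)ccc3[nH]c2=O)cc1` gives in this assay a limit, > 5000 nM. The step of an at least 1.5-fold higher number from compound 1 to compound 2 (0.19 log units; that floor lies within the scatter) rests on a limit (the limit of > 10000 nM in this assay, at which 1 of the 3 values shown sits), and the step that the limit leaves unreadable from compound 1 to compound 3 rests on a limit (the limit of > 5000 nM in this assay, at which 1 of the 3 values shown sits); neither step is readable in size.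

Compound 4 `CCc1ccc2[nH]c(=O)c(CN(Cc3ccc(C(C)(C)C)cc3)C(C)c3ccc(F)cc3)cc2c1` differs from compound 2 by 1-(4-fluorophenyl)ethyl in place of 4-(methoxymethoxy)benzyl on an amine nitrogen. Among the compounds with values here, the change to compound 3 also touched the 4-(methoxymethoxy)benzyl group, but its size is unreadable, so no measured step gives a direction for this move. With both neighbouring values at or near the upper limit, no step beyond the scatter is expected in this assay, and the step that the limit leaves unreadable from compound 2 to compound 4 is an estimate only. For compound 4 the expected value in this assay is 12000 nM, within 5000 nM to 40000 nM, most likely again reported as a limit.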

Compound 4, half-maximal cytotoxic concentration: 2800 nM
Compound 4: middle estimate off by 4.3-fold (0.63 log units), on the high side; the whole stated range lies above it.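

Within the data shown here, at this amine nitrogen, 1-(4-fluorophenyl)ethyl in place of 4-(methoxymethoxy)benzyl gives in this assay an at least 3.5-fold lower number from compound 2 to compound 4 (0.55 log units; beyond the scatter), the only step in the set that can be read as lying beyond the scatter. Among these compounds, this position is therefore not silent in this test: the replacement moves the read-out towards higher toxicity, while the earlier steps were either within the scatter or unreadable. The size of the step is only a floor, because compound 2 sits at a limit of the test: the limit of > 10000 nM in this assay, at which 1 of the 4 values shown sits.

The compounds shown do not separate the fluorine from the chain methyl of 1-(4-fluorophenyl)ethyl, or from the loss of methoxymethoxy, as the source of the lower number. As far as these compounds go, how a plain 4-fluorobenzyl or a benzyl carrying a carboxylic acid would read on this nitrogen in this assay also remains open.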